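The compounds below may be only part of what the source reports. "The series", "measured", "known", "first", "only" and "open" are said of these compounds alone.

Measured so far: compound 1 `COC(=O)CNC(=O)c1ccc(C(=O)NC[C@@H]2COc3ccccc3O2)cc1-c1ccccc1C` with 89000 nM in a functional assay (HSMC cells, Homo sapiens) for antiproliferative activity, with a stated time of 72 h (a higher number here means a weaker inhibitor, a lower number a stronger inhibitor), and compound 2 `COC(=O)CNC(=O)c1ccc(C(=O)NC[C@@H]2COc3ccccc3O2)cc1-c1ccccc1OC` with 76000 nM in this assay.

Compound 1 gives the highest of the two numbers; its nearest neighbour is compound 2, and the change from compound 1 to compound 2 is a 1.2-fold lower number from compound 1 to compound 2 (0.07 log units; within the scatter), brought about by methoxy in place of methyl on an aromatic carbon. Compound 3 `COC(=O)[C@H](CC(C)C)NC(=O)c1ccc(C(=O)NC[C@@H]2COc3ccccc3O2)cc1-c1ccccc1C` has not been measured. It differs from compound 1 by isobutyl in place of hydrogen on a saturated chain carbon bound to an amide-type nitrogen and a carbonyl carbon. Among the measured compounds shown here, the only measured step concerns the aromatic substituent and leaves the chain untouched, so no measured step bears on this change, and the two known values simply show two weak inhibitors close together. In this assay compound 3 is therefore expected to stay in the same weak region, with a step of a 1.5-fold lower number from compound 1 to compound 3 (0.17 log units; within the scatter) that carries little confidence in either direction. The estimate for compound 3 is 60000 nM, with a range from 15000 nM to 200000 nM.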

Compound 3, half-maximal inhibitory concentration: 88000 nM
Beside the measured number, compound 3's estimate is 1.5-fold (0.17 log units) below it; the measured number falls inside the stated range.
By their numbers in this assay, from the lowest: compounds 2, 3 and 1 (each within the scatter of the next).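

On the saturated chain carbon bound to an amide-type nitrogen and a carbonyl carbon, isobutyl in place of hydrogen gives a 1.0-fold lower number from compound 1 to compound 3 (0.00 log units; within the scatter) in this assay. The earlier pair changed only the aromatic substituent, whereas this result shows that the chain position can carry an isobutyl group of 4 heavy atoms with the number staying within the scatter, so all three compounds remain close together. No measurement at hand speaks to what lies behind this result.

From the compounds shown here alone, whether an amine-bearing chain or a phenyl group on that same carbon would move the number beyond the scatter remains open, as does the effect of a carboxylic acid in place of methoxycarbonyl. Going by these compounds, it is also open whether isobutyl would give the same result alongside methoxy in place of methyl on the aromatic carbon.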